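The source may report more compounds than this note shows. Statements on the series, on what has been measured and on what is new or still open speak of the compounds shown alone.

In a physicochemical assay for solubility, measured as kinetic solubility (on this read-out higher numbers stand for higher solubility and lower numbers for lower solubility), compound 1 (`COc1cc(C)[nH]c(=O)c1CN1CCc2c(Cl)cc(-c3c(C)noc3C)c(Cl)c2C1=O`) gives 384000 nM, compound 2 (`COc1cc(C)[nH]c(=O)c1CN1CCc2c(Cl)cc([C@H](O)C3COC3)c(Cl)c2C1=O`) gives 234000 nM and compound 3 (`COc1cc(C)[nH]c(=O)c1CN1CCc2c(Cl)cc([C@@H](O)C3COC3)c(Cl)c2C1=O`) gives 582000 nM. Compound 1 is not separated from either neighbour: the readings show a 1.6-fold lower number from compound 1 to compound 2 (0.22 log units; within the scatter) and a 1.5-fold higher number from compound 1 to compound 3 (0.18 log units; within the scatter). The one gap beyond the scatter is a 2.5-fold higher number from compound 2 to compound 3 (0.40 log units; beyond the scatter), which goes with the fact that compounds 2 and 3 differ only in the configuration as drawn. Compound 4 (`Cc1cc(C)c(CN2CCc3c(Cl)cc(-c4c(C)noc4C)c(Cl)c3C2=O)c(=O)[nH]1`) differs from compound 1 by methyl in place of methoxy on an aromatic carbon, methyl in place of methoxy, opposite the ring nitrogen. For the measured compounds named here, none of the measured steps touches this position, so they give only the span of the series in this assay, and no direction follows from them. No step beyond the scatter is expected, and the estimated step is a 1.1-fold lower number from compound 1 to compound 4 (0.04 log units; within the scatter). The estimate for compound 4 is 350000 nM, with an expected range of 150000 nM to 700000 nM.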

Compound 4, solubility: 93000 nM
Estimate against measurement, compound 4: 3.8-fold (0.58 log units) above; the whole stated range lies above it.
By their numbers in this assay, from the lowest: compound 4; then compounds 2, 1 and 3 (each within the scatter of the next, the first and the last beyond it).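

The position opposite the ring nitrogen is not neutral in this assay: methyl in place of methoxy gives a 4.1-fold lower number from compound 1 to compound 4 (0.62 log units; beyond the scatter). This single exchange on an aromatic carbon, with the rest of compound 1 kept, moves the number beyond the scatter, which neither exchange of the other aromatic-carbon group in compound 2 or compound 3 did from compound 1.

On these data alone, whether an ethoxy group, a hydroxyl or an amine at this position would read like compound 1 or like compound 4 stays open. Nothing recorded for these compounds bears on the cause of this step.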